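The compounds below may be only part of what the source reports. "The series", "measured", "known", "first", "only" and "open" are said of these compounds alone.

Working notes on the series.

Within the data shown here, compound 3 `CC(=O)c1ccc(NC(=O)CN(C(=O)c2ccccc2)S(=O)(=O)c2ccc([N+](=O)[O-])cc2)cc1` gives 20.7% in a functional assay for inhibition, read by spectrophotometry, with a stated time of 20 min, tested at 5 mg/mL (a higher number here means a stronger effect of the compound at the concentration tested, a lower number a weaker effect), the highest of the three numbers measured so far. Compound 1 `CC(=O)c1ccc(NC(=O)CN(C(=O)c2ccccc2)S(=O)(=O)c2ccc(C)cc2)cc1` gives 18.7%, a number within the scatter of compound 3. Compound 2 `CC(=O)c1ccc(NC(=O)C2CC(O)CN2S(=O)(=O)c2ccc(C)cc2)cc1` gives 13%, also within the scatter of compound 3. Among the measured compounds shown here, the single one-place step measured, a number 2 percentage points higher from compound 1 to compound 3 (within the scatter), is within the scatter.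

Compound 4 `CC(=O)c1ccc(NC(=O)C(C(C)C)N(C(=O)c2ccccc2)S(=O)(=O)c2ccc([N+](=O)[O-])cc2)cc1` differs from compound 3 by isopropyl in place of hydrogen on a saturated chain carbon bound to an amide-type nitrogen and a carbonyl carbon. For the measured compounds named here, no measured step touches this place: the one step measured concerns the aromatic carbon carrying nitro or methyl, and compound 2 differs from compound 1 in more than one place, so its value cannot be read as a single change. There is no measured ground for expecting a shift beyond the scatter in this assay in either direction.

Compound 4 is therefore expected to give 20%, in the range 8% to 34%. The step of a number 0.7 percentage points lower from compound 3 to compound 4 (within the scatter) is expected to stay within the scatter.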

Compound 4, a percentage reported as inhibition, at one concentration (the size of the read-out at that concentration, not a potency): 27.4%
The estimate for compound 4 lay 7.4 percentage points below the measured number; low and high end bracket the measured number.
By their numbers in this assay, from the lowest: compounds 2, 1, 3 and 4 (each within the scatter of the next, the first and the last beyond it).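

Among these compounds, this is the first measured step at the saturated chain carbon bound to an amide-type nitrogen and a carbonyl carbon. In this assay, isopropyl in place of hydrogen at this carbon gives a number 6.7 percentage points higher from compound 3 to compound 4 (within the scatter) and so shows that this place accepts a branched group of 3 heavy atoms with no change beyond the scatter. No measurement given here accounts for the size of this step.

A single substituent at this carbon leaves open how a methyl, a longer chain, a phenyl ring, an amine or a carboxylic acid would read there. Also open, going by these compounds, are whether isopropyl gives a comparable step with methyl in place of nitro on the aromatic carbon, as in compound 1, and how the compounds compare in potency, since the read-out comes from one concentration.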